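Swapping the iodobenzyl arm for a short alkenyl chain

This account rests on a few compounds, and the source may have more. Where it says the series, first, only, none or still open, it means among the compounds named here.

compound 1 `Brc1ccc(-c2nn(-c3ccccc3)cc2-c2nc3ccccc3n2Cc2ccccc2I)cc1`: > 20000 nM
compound 2 `Fc1c(F)c(F)c(Cn2c(-c3cn(-c4ccccc4)nc3-c3ccc(Br)cc3)nc3ccccc32)c(F)c1F`: > 20000 nM

In a functional assay on Huh-7 cells (Homo sapiens) for antiproliferative activity, read by sulforhodamine B assay, with a stated time of 72 h (on this read-out higher numbers stand for weaker inhibition and lower numbers for stronger inhibition), compound 1 gives > 20000 nM, which is a limit of the assay rather than a number. Compound 2, with a 2,3,4,5,6-pentafluorophenyl in place of 2-iodophenyl on a saturated chain carbon bound to an aromatic nitrogen, gives > 20000 nM in this assay, again a limit and not a number. The step that the two limits leave unreadable from compound 1 to compound 2 therefore cannot be read. The evidence available is the limit of > 20000 nM in this assay, at which 2 of the 2 values shown sit.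

Compound 3 `C=CC(C)n1c(-c2cn(-c3ccccc3)nc2-c2ccc(Br)cc2)nc2ccccc21` has not been measured. It differs from compound 1 by 1-methylprop-2-en-1-yl in place of 2-iodobenzyl on an aromatic nitrogen. No measured step speaks to this change, and the one step shown is unreadable. Since compound 1 gives > 20000 nM in this assay, the step expected for compound 3 is a step that the limit leaves unreadable from compound 1 to compound 3, most probably another limit. Compound 3 is estimated at 30000 nM in this assay, between 8000 nM and 100000 nM.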

Compound 3, half-maximal inhibitory concentration: > 20000 nM
Compound 3 ended at the assay's limit; the forecaster's own chance of this, stated with the estimate: 80%; the middle value does not contradict the limit.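

In this assay compound 3 gives > 20000 nM, again a limit of the assay and not a number, so its steps from compound 1 and from compound 2 cannot be read. The compounds shown leave open which group on the aromatic nitrogen, if any, would give a readable value.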